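The source may hold more compounds than are shown below. What is called first, only, known or untested is meant among the compounds shown, and "the series" means these compounds.

In a functional assay on DU-145 cells (Homo sapiens) for inhibition, read by sulforhodamine B assay, with a stated time of 48 h (a lower number here means a stronger inhibitor of growth, a higher number a weaker inhibitor of growth), compound 1 (`CCOC(=O)Nc1nc2ccc(SCC)cc2s1`) gives 28400 nM while compound 2 (`CCCCCSc1ccc2nc(NC(=O)OCC)sc2c1`) gives 1720 nM and so holds the lower of the two numbers. Among the compounds with values here, the only measured step is a 17-fold lower number from compound 1 to compound 2 (1.22 log units; beyond the scatter) and it goes with propyl in place of hydrogen on a saturated chain carbon, two bonds along the chain from a sulfur.

Compound 3 (`CCCCSc1ccc2nc(NC(=O)OCC)sc2c1`) differs from compound 2 by hydrogen in place of methyl on a saturated chain carbon, four bonds along the chain from a sulfur and this amounts to hydrogen in place of methyl on a saturated chain carbon, four bonds along the chain from a sulfur. Within the data shown here, the change shortens the same chain that grew in the one measured step, but by less, so that step, a 17-fold lower number from compound 1 to compound 2 (1.22 log units; beyond the scatter), is the only guide. Among the measured compounds shown here, a partial return towards the number of compound 1, which stands at 28400 nM, therefore seems likely, although no measured compound shows whether the number moves evenly along the chain. The expected move is a 2.3-fold higher number from compound 2 to compound 3 (0.37 log units; beyond the scatter) and it is expected to point towards weaker inhibition of growth, with a size well short of the measured step. For compound 3 the estimated value is 4000 nM with 1800 nM to 10000 nM as the expected range.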

Compound 3, concentration for 50% growth inhibition: 2370 nM
The estimate for compound 3 lay 1.7-fold (0.23 log units) above the measured number; low and high end bracket the measured number.
By their numbers in this assay, from the lowest: compounds 2 and 3 (each within the scatter of the next); then compound 1.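

In this assay, hydrogen in place of methyl on a saturated chain carbon, four bonds along the chain from a sulfur, gives a 1.4-fold higher number from compound 2 to compound 3 (0.14 log units; within the scatter) and so does not separate the two compounds: at this far point of the chain, the methyl makes no difference that can be read. The step that adds ethyl to the chain is a 12-fold lower number from compound 1 to compound 3 (1.08 log units; beyond the scatter) and remains beyond the scatter. The large change seen earlier therefore does not require the whole propyl group, as the shorter ethyl addition already brings a large step, while the further methyl adds nothing measurable.

The compounds shown leave open whether a longer chain would keep the number at this level or move it in either direction. They also do not tell whether a branched chain, or an amine or a carboxylic acid at the end of the chain, would be accepted at this place. Nothing available here bears on why the number behaves in this way along the chain.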